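Substituent on the ring amine nitrogen: compound 4 outlook

The compounds below may be only part of what the source reports. "The series", "measured", "known", "first", "only" and "open" are said of these compounds alone.

Within the data shown here, compound 3 `Nc1ccccc1NC(=O)c1ccc(CSC(=S)N2CCN(C3CCCCC3)CC2)cc1` gives 89.9% in a functional assay on A-375 cells (Homo sapiens) for antiproliferative activity, read by CCK-8 assay, with a stated time of 72 h, tested at 8 uM (on this read-out higher numbers stand for a stronger effect at the one concentration tested and lower numbers for a weaker effect), the highest of the three numbers so far, though compound 1 sits within the scatter of it. Compound 1 `Nc1ccccc1NC(=O)c1ccc(CSC(=S)N2CCN(Cc3ccccn3)CC2)cc1` gives 82.4% in this assay. Compound 2 `Nc1ccccc1NC(=O)c1ccc(CSC(=S)N2CCN(c3ccc(Cl)cc3)CC2)cc1` gives 29% in this assay. The two relevant comparisons are a number 7.5 percentage points higher from compound 1 to compound 3 (within the scatter) and a number 60.9 percentage points higher from compound 2 to compound 3 (beyond the scatter). Compound 4 `Nc1ccccc1NC(=O)c1ccc(CSC(=S)N2CCN(Cc3ccncc3)CC2)cc1` is not yet measured; it differs from compound 3 by (pyridin-4-yl)methyl in place of cyclohexyl on an amine nitrogen in a ring. Among the measured compounds shown here, the nearer comparison is the one from compound 1, where a pyridinylmethyl group was exchanged for cyclohexyl without a shift beyond the scatter; the 4-chlorophenyl comparison is more remote. Compound 4 is therefore expected to show no step beyond the scatter, with a number 6.9 percentage points lower from compound 3 to compound 4 (within the scatter). The estimate for compound 4 is 83%, between 62% and 95%.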

Compound 4, a percentage reported as inhibition, at one concentration (the size of the read-out at that concentration, not a potency): 89.5%
The estimate for compound 4 lay 6.5 percentage points below the measured number, and the stated range covers the measured number.
By their numbers in this assay, from the lowest: compound 2; then compounds 1, 4 and 3 (each within the scatter of the next).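

In this assay pyridin-4-yl in place of pyridin-2-yl on the saturated chain carbon gives a number 7.1 percentage points higher from compound 1 to compound 4 (within the scatter), so this exchange leaves the read-out unmoved. (Pyridin-4-yl)methyl in place of cyclohexyl gives a number 0.4 percentage points lower from compound 3 to compound 4 (within the scatter) and in place of 4-chlorophenyl gives a number 60.5 percentage points higher from compound 2 to compound 4 (beyond the scatter), so an aromatic ring with one hetero atom and a ring of carbon only are both compatible with a high read-out here, and compound 2 alone stays low. No available data explain these results. Going by these compounds, whether the low value of compound 2 goes with the chlorine or with the missing chain carbon stays open; 4-chlorobenzyl or unsubstituted phenyl on that amine nitrogen would separate the two. With one concentration only, the three high compounds also remain unranked by potency.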